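This account rests on a few compounds, and the source may have more. Where it says the series, first, only, none or still open, it means among the compounds named here.

In a functional assay on CHO cells for positive allosteric modulation of metabotropic glutamate receptor 2 (Homo sapiens), with a stated time of 30 min (on this read-out lower numbers stand for an effect already at smaller amounts and higher numbers for an effect only at larger amounts of compound), three compounds that share one core have been measured. Compound 1 `N#Cc1c(N2CCC(c3ccccc3)CC2)ccn(CC2CC2)c1=O` gives 151 nM. Compound 2 `N#Cc1c(N2CCC(c3ccccc3F)CC2)ccn(CC2CC2)c1=O`, which carries a fluoro on one aromatic carbon, gives 81 nM. Compound 3 `N#Cc1c(N2CCC(c3ccccc3Cl)CC2)ccn(CC2CC2)c1=O`, with a chloro at the same aromatic carbon, gives 49 nM, the lowest number of the three; the step of a 3.1-fold lower number from compound 1 to compound 3 (0.49 log units; beyond the scatter) is the only one here that clearly exceeds the scatter, while a 1.9-fold lower number from compound 1 to compound 2 (0.27 log units; within the scatter) and a 1.7-fold lower number from compound 2 to compound 3 (0.22 log units; within the scatter) do not.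

Compound 4 `COc1ccccc1C1CCN(c2ccn(CC3CC3)c(=O)c2C#N)CC1` has not yet been measured. It differs from compound 3 in one place: methoxy in place of chloro on an aromatic carbon. Of the measured steps, the two that touch this aromatic carbon bear on the change, namely a 3.1-fold lower number from compound 1 to compound 3 (0.49 log units; beyond the scatter) and a 1.7-fold lower number from compound 2 to compound 3 (0.22 log units; within the scatter); both show that a halogen there moves the number somewhat downward, but neither says what a methoxy does, and the two groups have little in common beyond their position. Within the data shown here, no measured pair tests methoxy against chloro.

Compound 4 is therefore expected to land near compound 3 or a little higher, with a 2.0-fold higher number from compound 3 to compound 4 (0.31 log units; beyond the scatter) as the estimated step, and its value is estimated at 100 nM within a range from 40 nM to 250 nM.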

Compound 4, half-maximal effective concentration: 35 nM
The estimate for compound 4 lay 2.9-fold (0.46 log units) above the measured number, and the stated range ends above it.
By their numbers in this assay, from the lowest: compounds 4, 3, 2 and 1 (each within the scatter of the next, the first and the last beyond it).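

Replacing chloro with methoxy on this aromatic carbon gives in this assay a 1.4-fold lower number from compound 3 to compound 4 (0.15 log units; within the scatter) and so leaves the two groups indistinguishable, even though methoxy brings two heavy atoms and a hydrogen-bond acceptor where chloro has one heavy atom and no acceptor. The position is therefore not tied to a halogen, as the oxygen-linked group also reaches this level. Measured against the other two compounds, methoxy gives a 4.3-fold lower number from compound 1 to compound 4 (0.63 log units; beyond the scatter) and also a 2.3-fold lower number from compound 2 to compound 4 (0.36 log units; beyond the scatter) and both steps lie beyond the scatter, so methoxy separates clearly from fluoro, a separation that chloro did not show. No measurement is available that would explain why chloro and methoxy behave alike here.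

The compounds shown carry only hydrogen, fluoro, chloro or methoxy at this carbon, so it remains open whether a longer ether such as ethoxy, an amine such as dimethylamino or a carboxylic acid would keep the number at this level. On these data alone, it also remains open whether methoxy would give a similar number on a different carbon of the same aromatic ring.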